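The source may hold more compounds than are shown below. What is called first, only, known or untested is meant among the compounds shown, and "the series" means these compounds.

Compound 2 `CC(C)CSC(CCC/C=C(\c1ccccc1)c1cccnc1)C(=O)O` gives 110 nM in an assay (Equus caballus) for inhibition of Thromboxane-A synthase (Homo sapiens), using microsomes; on this read-out lower numbers stand for stronger inhibition and higher numbers for weaker inhibition. For the measured compounds named here, of the two numbers so far, compound 2 stands highest; its only neighbour, compound 1 `C=C(C)C(CCC/C=C(\c1ccccc1)c1cccnc1)C(=O)O`, gives 28 nM in this assay, and the single measured step, a 3.9-fold higher number from compound 1 to compound 2 (0.59 log units; beyond the scatter), is modest but beyond the scatter.

Compound 3 `O=C(O)C(CCC/C=C(\c1ccccc1)c1cccnc1)Sc1ccccc1` is the next compound to be measured in this assay. It differs from compound 2 by phenyl in place of isobutyl on a sulfur. Going by the values given here, no measured step bears directly on this exchange: the one step available, a 3.9-fold higher number from compound 1 to compound 2 (0.59 log units; beyond the scatter), concerns the group on the saturated chain carbon bound to the carbonyl carbon, not what is carried by the sulfur. What it shows is that changing the group at that carbon moves the number by a modest amount, so a change one bond further out is expected to move it by no more than that, in either direction.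

Compound 3 is therefore expected to give about 100 nM, with a range from 30 nM to 350 nM, which amounts to a 1.1-fold lower number from compound 2 to compound 3 (0.04 log units; within the scatter) and is not expected to go beyond the scatter.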

Compound 3, half-maximal inhibitory concentration: 33 nM
Estimate against measurement, compound 3: 3.0-fold (0.48 log units) above; low and high end bracket the measured number.
By their numbers in this assay, from the lowest: compounds 1 and 3 (each within the scatter of the next); then compound 2.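

The group carried by the sulfur matters in its own right: in this assay, there is a 3.3-fold lower number from compound 2 to compound 3 (0.52 log units; beyond the scatter), so an exchange one bond further out than the earlier one still moves the number beyond the scatter. The sulfur itself does not tie the series to the higher number, since the comparison with the 1-methylethenyl compound gives a 1.2-fold higher number from compound 1 to compound 3 (0.07 log units; within the scatter), and the rise seen in a 3.9-fold higher number from compound 1 to compound 2 (0.59 log units; beyond the scatter) therefore appears with isobutylsulfanyl but not with phenylsulfanyl among these compounds. No independent measurement is available to explain the difference between isobutyl and phenyl on the sulfur.

The compounds shown leave open whether the phenyl ring's aromatic character matters or whether any ring of that size would serve, a question that a cyclohexyl on the sulfur would address, and whether a methoxy group or a chlorine on the phenyl would shift the number further. They also leave open whether the sulfur can give way to an oxygen or a methylene while the phenyl stays in place.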